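Bromo for methyl: expected potency of compound 3

The compounds below may be only part of what the source reports. "The series", "measured", "known", "first", "only" and "open" are said of these compounds alone.

Working notes on the series. The shared core of compound 1 `O=C(Nc1cccc2cccnc12)c1cnc(Cl)cn1` and compound 2 `Cc1ccc(C(=O)Nc2cccc3cccnc23)cn1` carries an amide to a six-membered aromatic ring with one nitrogen. In a functional assay on BXPC-3 cells (Homo sapiens) for inhibition, read by MTT assay, with a stated time of 72 h (on this read-out lower numbers stand for stronger inhibition and higher numbers for weaker inhibition), compound 1 reaches only the assay limit of > 10000 nM. In this assay compound 2 likewise returns only the assay limit of > 10000 nM. On the numbers shown, compound 2 therefore stands at the limit and no ordering against compound 1 is possible; both values sit at the limit of > 10000 nM in this assay, at which 2 of the 2 values shown sit. Compound 3 `O=C(Nc1cccc2cccnc12)c1ccc(Br)nc1` differs from compound 2 by bromo in place of methyl on an aromatic carbon. Among the measured compounds shown here, no measured step gives a size for such a change, so no shift beyond the scatter is expected; the step from compound 2 to compound 3 is estimated at a step that the limit leaves unreadable from compound 2 to compound 3. Compound 3 is expected to give about 20000 nM in this assay, with a range of 5000 nM to 80000 nM, most likely again reported only as a limit.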

Compound 3, half-maximal inhibitory concentration: > 10000 nM
Compound 3: only a limit was reported (the forecaster's own chance of this, stated with the estimate: 75%); the middle value lies beyond the limit too.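

In this assay, among the compounds shown here, compound 3 is reported only as a limit (> 10000 nM), and with compound 2 also at a limit, no step between compound 2 and compound 3 can be read. The compounds shown leave open how large an effect bromo in place of methyl has, and which change to the shared core would give a value inside the assay range.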